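The source may report more compounds than this note shows. Statements on the series, on what has been measured and on what is new or still open speak of the compounds shown alone.

Within the data shown here, compound 3 `Clc1ccc(Cc2nn3c(Br)c(-c4ccc(Br)cc4)nc3s2)cc1` is the only member of this small set to give a number: in a functional assay on HeLa cells (Homo sapiens) for cytotoxicity, with a stated time of 72 h (on this read-out lower numbers stand for stronger inhibition and higher numbers for weaker inhibition), compound 3 gives 188000 nM. Compound 1 `Clc1ccc(Cc2nn3cc(-c4ccc(Br)cc4)nc3s2)cc1` reaches only a limit of this assay, > 250000 nM. Compound 2 `Cc1ccc(-c2cn3nc(Cc4ccc(Cl)cc4)sc3n2)cc1` likewise reaches only a limit, > 250000 nM. Among the measured compounds shown here, the one readable step, an at least 1.3-fold lower number from compound 1 to compound 3 (0.12 log units; that floor lies within the scatter), stays within the scatter, while a step that the two limits leave unreadable from compound 1 to compound 2 cannot be sized because of the limit of > 250000 nM in this assay, at which 2 of the 3 values shown sit. Compound 4 `O=[N+]([O-])c1ccc(-c2nc3sc(Cc4ccc(Cl)cc4)nn3c2Br)cc1` differs from compound 3 by nitro in place of bromo on an aromatic carbon. For the measured compounds named here, no measured step touches this nitro group, so the only guide is that a small change on the same ring left the number essentially unchanged. The step of a 1.3-fold lower number from compound 3 to compound 4 (0.10 log units; within the scatter) is therefore expected to stay within the scatter, and compound 4 is estimated at 150000 nM, between 50000 nM and 250000 nM.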

Compound 4, half-maximal inhibitory concentration: > 250000 nM
Compound 4: only a limit was reported; the forecaster's own chance of this, stated with the estimate: 40%; at least 1.6-fold (0.22 log units) between middle value and limit.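

Nitro in place of bromo, para to a large group on the six-membered aromatic ring of carbon only, gives an at least 1.3-fold higher number from compound 3 to compound 4 (0.12 log units; that floor lies within the scatter). Unlike the earlier steps at this place, this one starts from a compound with a measured number, yet nitro shows no stronger inhibition in this assay. The value of compound 4 is a limit, and the true size of the step stays unknown because the reading stops there: the limit of > 250000 nM in this assay, at which 3 of the 4 values shown sit.

From the compounds shown here alone, whether an amine or a carboxylic acid at this place would give a clearly lower number remains open.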